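Swapping tert-butyl for 2-methoxyphenyl: an expected small step

A few compounds are considered here, and "the series" means these few. Any claim that something is new, unique, unknown or untested is made for them only; others in the source may bear on it.

Measured compounds:
compound 1, `CC(C)(C)c1cn(C[C@H](O)[C@H]2OC(=O)C(OCc3ccccc3)=C2OCc2ccccc2)nn1`: 34000 nM
compound 2, `COc1ccc(-c2cn(C[C@H](O)[C@H]3OC(=O)C(OCc4ccccc4)=C3OCc3ccccc3)nn2)cc1`: 28300 nM

Both compounds were tested in a functional assay on A549 cells (Homo sapiens) for antiproliferative activity, read by MTT assay, with a stated time of 72 h; on this read-out higher numbers stand for weaker inhibition and lower numbers for stronger inhibition. On the numbers shown, compound 1 stands at the highest of the two, with compound 2 nearest; the step of a 1.2-fold lower number from compound 1 to compound 2 (0.08 log units; within the scatter) lies within the scatter, so the two cannot be told apart on this read-out. That step placed a 4-methoxyphenyl group where a tert-butyl group had been, on an aromatic carbon.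

Compound 3, `COc1ccccc1-c1cn(C[C@H](O)[C@H]2OC(=O)C(OCc3ccccc3)=C2OCc2ccccc2)nn1`, has not yet been measured. It differs from compound 1 as follows: 2-methoxyphenyl in place of tert-butyl on an aromatic carbon. Within the data shown here, the only measured step that bears on this change is the one already stated, in which a methoxyphenyl group of a different kind took the same place and moved the number only within the scatter. On that basis no step beyond the scatter is expected in this assay for compound 3, in either direction. The estimate for compound 3 is 30000 nM, with a range from 15000 nM to 60000 nM. This corresponds to an expected step of a 1.1-fold lower number from compound 1 to compound 3 (0.05 log units; within the scatter).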

Compound 3, half-maximal inhibitory concentration: > 100000 nM
Compound 3 was reported as a limit; the forecaster's own chance of this, stated with the estimate: 15%; middle value at least 3.3-fold (0.52 log units) from the limit.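

Compound 3 is reported only as a limit in this assay, not as an exact number: the limit of > 100000 nM in this assay, at which 1 of the 3 values shown sits. With 2-methoxyphenyl in place of tert-butyl, the result is an at least 2.9-fold higher number from compound 1 to compound 3 (0.46 log units; beyond the scatter), so this aromatic carbon is not as indifferent to its substituent as the earlier pair of compounds suggested. The direct comparison of the two methoxyphenyl groups gives an at least 3.5-fold higher number from compound 2 to compound 3 (0.54 log units; beyond the scatter), which shows that in this series the placement of the methoxy group on the phenyl ring can matter, even though 4-methoxyphenyl and tert-butyl could not be told apart on this read-out.

The full size of both steps remains open, since each is bounded on one side only, and these three compounds do not reveal why the 2-methoxyphenyl compound falls short. Nor do they show whether the loss belongs to the methoxy group itself or to any group at that place on the phenyl ring, a question that 3-methoxyphenyl, unsubstituted phenyl, 2-methylphenyl or 2-aminophenyl at the same carbon would bear on.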